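The compounds below may be only part of what the source reports. "The series", "measured", "known", "first", "only" and "open" are said of these compounds alone.

Working notes on the series in a functional assay on the whole organism (strain Wistar) for inhibition, with Rattus norvegicus as the target, read by paw edema, with a stated time of 1 h, at a dose of 100 mg/kg; on this read-out lower numbers stand for less inhibition and higher numbers for more inhibition at the one dose given (going by the name of the read-out). The parent is compound 1 `COc1cc2c(cc1OC)C(CC(=O)Nc1ccccc1)CC2`, which gives 31.3%. Compound 2 `COc1cc2c(cc1OC)C(CC(=O)Nc1ccc(Br)cc1)CC2` gives 50%, and the step of a number 18.7 percentage points higher from compound 1 to compound 2 (beyond the scatter) comes from bromo in place of hydrogen on an aromatic carbon. Compound 3 `COc1cc2c(cc1OC)C(CC(=O)Nc1ccccc1C)CC2` gives 21.9%, the lowest of the three numbers; the step of a number 9.4 percentage points lower from compound 1 to compound 3 (within the scatter) stays within the scatter, while a number 28.1 percentage points lower from compound 2 to compound 3 (beyond the scatter) lies beyond it.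

The next step goes from compound 3 to compound 4 `COc1cc2c(cc1OC)C(CC(=O)Nc1cccc(C)c1)CC2`, a change of 3-methylphenyl in place of 2-methylphenyl on an amide-type nitrogen. For the measured compounds named here, no measured step bears directly on this rearrangement: the only change at the aryl group measured so far is the step from compound 1 to compound 3, and it was within the scatter. The bromo step from compound 1 to compound 2 was modest and upward, but it concerns a different group. With compound 1 and compound 3 within the scatter of each other, the expected step of a number 6.1 percentage points higher from compound 3 to compound 4 (within the scatter) in this assay is none beyond the scatter, with a wide range to cover the absence of a matching precedent. Compound 4 is therefore estimated at 28%, between 12% and 45%.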

Compound 4, a percentage reported as inhibition, in the whole organism at one dose (the size of the read-out at that dose, not a potency): 37.5%
Compound 4: the middle estimate sits 9.5 percentage points below what was measured, and the stated range covers the measured number.
By their numbers in this assay, from the lowest: compounds 3, 1 and 4 (each within the scatter of the next, the first and the last beyond it); then compound 2.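

In this assay, for the compounds shown here, with the same atoms joined differently, 3-methylphenyl in place of 2-methylphenyl on the amide-type nitrogen gives a number 15.6 percentage points higher from compound 3 to compound 4 (beyond the scatter), so at this position the place of the methyl on the aryl group alone separates two compounds, which the earlier compounds could not show. Against the unsubstituted parent neither methyl compound stands apart: the new step reads a number 6.2 percentage points higher from compound 1 to compound 4 (within the scatter) and the earlier one reads a number 9.4 percentage points lower from compound 1 to compound 3 (within the scatter), so the separation appears only when the two methylphenyl compounds are compared directly. The 4-bromophenyl compound also remains apart from the better of the two, with a number 12.5 percentage points lower from compound 2 to compound 4 (beyond the scatter), and nothing at hand accounts for any of these steps.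

Whether the bromo gain holds with bromo elsewhere on the aryl group stays open, as 4-bromophenyl is the only bromo group among the compounds shown. Also open, going by these compounds, is how an amine or a carboxylic acid in place of the methyl would read in this assay, and whether these gaps hold at another dose or time.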